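A few compounds are considered here, and "the series" means these few. Any claim that something is new, unique, unknown or untested is made for them only; others in the source may bear on it.

In a functional assay on P388 cells (Mus musculus) for cytotoxicity (a higher number here means that more compound is needed for the effect, a lower number that less compound is needed), compound 1 `CCCOc1cc(-c2ccccc2)nc2ccccc12` gives 6.9 ug/mL. Compound 2 `CCCCOc1cc(-c2ccccc2)nc2ccccc12` gives > 10 ug/mL, which is a limit of the assay and not a number, so its standing is known only from that limit. The change to compound 3 `CC(C)COc1cc(-c2ccccc2)nc2ccccc12` is isopropyl in place of propyl on a saturated chain carbon bound to an oxygen on an aromatic ring, which reads one bond further out as butoxy to isobutoxy. The same atoms are kept, joined differently. Among the measured compounds shown here, only one measured step bears on this: an at least 1.4-fold higher number from compound 1 to compound 2 (0.16 log units; that floor lies within the scatter). That step adds a methyl in place of hydrogen on the chain and does not rearrange it, so it offers only a loose guide. On that basis, no shift beyond the scatter is expected in this assay, and another limit remains quite possible. The expected step is a step that the limit leaves unreadable from compound 2 to compound 3. Compound 3 is estimated at 11 ug/mL, with an expected range from 5 ug/mL to 25 ug/mL.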

Compound 3, half-maximal effective concentration: > 10 ug/mL
Compound 3 ended at the assay's limit; the forecaster's own chance of this, stated with the estimate: 50%; the middle value lies beyond the limit too.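

In this assay, rearranging butoxy to isobutoxy at this position, with the same atoms joined differently, does not return the series to a readable value: compound 3 gives > 10 ug/mL, which is a limit of the assay and not a number. Branching the chain by a methyl in place of hydrogen on a saturated chain carbon bound to two saturated chain carbons gives an at least 1.4-fold higher number from compound 1 to compound 3 (0.16 log units; that floor lies within the scatter), so this step does not separate the two compounds. The step between the butoxy and isobutoxy compounds cannot be read, so straight and branched chains are not told apart here, and the data end at this: the limit of > 10 ug/mL in this assay, at which 2 of the 3 values shown sit.

From the compounds shown here alone, how far compound 2 and compound 3 lie past the limit, and whether they differ at all, remains open. Going by these compounds, whether an ethoxy chain, or an amine carried on the chain, gives a number in this assay also stays open.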